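The source may hold more compounds than are shown below. What is called first, only, known or untested is meant among the compounds shown, and "the series" means these compounds.

Compound 2, with the structure `O=C1N=C(N2CCC[C@H]2C(=O)Nc2ccc3ncnc(Nc4cccc(Cl)c4)c3c2)S/C1=C/c1ccc(-c2ccccc2)cc1`, gives 24200 nM in a functional assay on A549 cells (Homo sapiens) for antiproliferative activity, read by MTT assay; a lower number here means a stronger inhibitor, a higher number a weaker inhibitor. Among the three measured compounds it has the second highest number: compound 1 `COc1ccc(/C=C2/SC(N3CCC[C@H]3C(=O)Nc3ccc4ncnc(Nc5cccc(Cl)c5)c4c3)=NC2=O)cc1` gives 31700 nM, and the step of a 1.3-fold lower number from compound 1 to compound 2 (0.12 log units; within the scatter) stays within the scatter, while compound 3 `O=C1N=C(N2CCC[C@H]2C(=O)Nc2ccc3ncnc(Nc4cccc(Cl)c4)c3c2)S/C1=C/c1cccs1` gives 6100 nM, reached by the step of a 4.0-fold lower number from compound 2 to compound 3 (0.60 log units; beyond the scatter). Compound 4 `O=C1N=C(N2CCC[C@H]2C(=O)Nc2ccc3ncnc(Nc4cccc(Cl)c4)c3c2)S/C1=C/c1ccccc1[N+](=O)[O-]` differs from compound 2 in one place: 2-nitrophenyl in place of 4-phenylphenyl on a double-bonded chain carbon bound to a double-bonded ring carbon. Among the measured compounds shown here, no measured step exchanges the 4-phenylphenyl for a 2-nitrophenyl, so the only guidance is that leaving the 4-phenylphenyl for a smaller thiophen-2-yl lowered the number modestly in the step from compound 2 to compound 3, and from compound 1 to compound 3 the step of a 5.2-fold lower number from compound 1 to compound 3 (0.72 log units; beyond the scatter) pointed the same way. A modest lowering is therefore expected, giving compound 4 an estimated 13000 nM, within 4500 nM to 38000 nM, which would mean an expected step of a 1.9-fold lower number from compound 2 to compound 4 (0.27 log units; within the scatter).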

Compound 4, half-maximal inhibitory concentration: > 50000 nM
Compound 4 ended at the assay's limit; the forecaster's own chance of this, stated with the estimate: 5%; middle value at least 3.8-fold (0.58 log units) from the limit.
By their numbers in this assay, from the lowest: compound 3; then compounds 2 and 1 (each within the scatter of the next). At a limit, above all of these: compound 4.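

In this assay compound 4 gives > 50000 nM, which is a limit of the assay and not a number. At this carbon, a smaller group does not by itself bring a lower number: 2-nitrophenyl has fewer heavy atoms than 4-phenylphenyl, yet the result is an at least 2.0-fold higher number from compound 2 to compound 4 (0.31 log units; beyond the scatter), against thiophen-2-yl it is an at least 8.1-fold higher number from compound 3 to compound 4 (0.91 log units; beyond the scatter), and against 4-methoxyphenyl it is an at least 1.5-fold higher number from compound 1 to compound 4 (0.19 log units; that floor lies within the scatter).

Still open, on these data alone, is how an amine or a carboxylic acid in place of the nitro group on that phenyl ring would behave.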